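The source may report more compounds than this note shows. Statements on the series, on what has been measured and on what is new or still open speak of the compounds shown alone.

Compound 1 `COc1cccc(-c2nn3cc(-c4cccc(N)c4)nc3s2)c1`, in a functional assay on HeLa cells (Homo sapiens) for inhibition, read by cell counting, with a stated time of 4 days (on this read-out lower numbers stand for stronger inhibition and higher numbers for weaker inhibition), compound 1 gives 230000 nM.
Compound 2 `C=C(Br)C(=O)Nc1cccc(-c2cn3nc(-c4ccc(Cl)cc4)sc3n2)c1`, in this assay compound 2 gives 3000 nM.
Compound 3 `Nc1cccc(-c2cn3nc(-c4ccc(Cl)cc4)sc3n2)c1`, in this assay compound 3 gives 160000 nM.

Compound 3 stands second highest of the three numbers; compound 1 lies nearest, within the scatter, while compound 2 lies far below. For the measured compounds named here, the only step measured here is a 53-fold higher number from compound 2 to compound 3 (1.73 log units; beyond the scatter), a large change that touches the nitrogen on the aromatic ring and says nothing about the other end of the molecule. Compound 4 `Cc1ccc(-c2nn3cc(-c4cccc(N)c4)nc3s2)cc1` differs from compound 3 by methyl in place of chloro on an aromatic carbon. Going by the values given here, no measured step bears on this change. A step of no size beyond the scatter is therefore expected, and compound 4 is estimated to give 160000 nM (range 60000 nM to 400000 nM), which means the expected step of no change at the digits printed from compound 3 to compound 4 (within the scatter).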

Compound 4, half-maximal inhibitory concentration: 8900 nM
Compound 4: middle estimate off by 18-fold (1.25 log units), on the high side; the whole stated range lies above it.
By their numbers in this assay, from the lowest: compound 2; then compound 4; then compounds 3 and 1 (each within the scatter of the next).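

In this assay there is an 18-fold lower number from compound 3 to compound 4 (1.25 log units; beyond the scatter) when methyl replaces chloro, a swap of one heavy atom that leaves the count of hydrogen-bond donors and acceptors unchanged. The earlier step showed a large change only at the ring nitrogen, whereas this one shows that the 4-chlorophenyl position also matters, even with that nitrogen left unsubstituted. Nothing given here explains the shift. Still open, on these data alone, is whether an ethyl group, an amine or a carboxylic acid at this position would continue the change. Also open, as far as these compounds go, is how the (1-bromoethenyl)carbonyl group would behave alongside 4-methylphenyl.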